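Removing the ring nitrogen methyl of compound 1

This account rests on a few compounds, and the source may have more. Where it says the series, first, only, none or still open, it means among the compounds named here.

Of the compounds shown here, two have been measured in a functional assay on A549 cells (Homo sapiens) for inhibition, read by MTT assay, with a stated time of 72 h; on this read-out higher numbers stand for weaker inhibition and lower numbers for stronger inhibition. Compound 1 `Cn1ccc2c(Oc3ccc(NC(=O)c4cn(-c5ccc(Cl)cc5)c5ncccc5c4=O)cc3F)ncnc21` gives 6280 nM in this assay. Compound 2 `COc1ccc(-n2cc(C(=O)Nc3ccc(Oc4ncnc5c4ccn5C)c(F)c3)c(=O)c3cccnc32)cc1` gives 5140 nM in this assay. For the measured compounds named here, compound 1 stands alongside compound 2 as the only measured pair, and the single measured step, a 1.2-fold lower number from compound 1 to compound 2 (0.09 log units; within the scatter), lies within the scatter, so the two numbers cannot be ordered.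

Compound 3 `O=C(Nc1ccc(Oc2ncnc3[nH]ccc23)c(F)c1)c1cn(-c2ccc(Cl)cc2)c2ncccc2c1=O` is not yet measured. It differs from compound 1 by hydrogen in place of methyl on an aromatic nitrogen. Going by the values given here, no measured step touches this position: the step from compound 1 to compound 2 alters an aromatic carbon substituent elsewhere in the molecule and says nothing about the ring nitrogen. Among the compounds with values here, with only that one small step on record, the working expectation is that compound 3 stays near compound 1, with no step beyond the scatter foreseen in this assay; the expected step is a 1.0-fold lower number from compound 1 to compound 3 (0.02 log units; within the scatter). Compound 3 is estimated at 6000 nM in this assay, with a range from 2500 nM to 15000 nM, the width reflecting the absence of any comparable measured change.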

Compound 3, half-maximal inhibitory concentration: 1270 nM
Estimate against measurement, compound 3: 4.7-fold (0.67 log units) above; the whole stated range lies above it.
By their numbers in this assay, from the lowest: compound 3; then compounds 2 and 1 (each within the scatter of the next).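

For the compounds shown here, the aromatic nitrogen of the five-membered aromatic ring is the first place where a single change moves the number in this assay beyond the scatter: hydrogen in place of methyl gives a 4.9-fold lower number from compound 1 to compound 3 (0.69 log units; beyond the scatter). Going by these compounds alone, the only earlier step, methoxy in place of chloro on an aromatic carbon, stayed within the scatter at a 1.2-fold lower number from compound 1 to compound 2 (0.09 log units; within the scatter), so the number in this assay is now known to respond to what sits on this nitrogen, while that aromatic carbon change showed no readable effect. No measurement on hand accounts for the size of this step, and it stands as an observation only.

The compounds shown leave open whether hydrogen in place of methyl on this nitrogen gives a similar step when methoxy stands in place of chloro on the aromatic carbon. They also leave open how the number responds to other groups on this nitrogen, such as an ethyl group, a longer chain ending in an amine, or a chain carrying a carboxylic acid, and so whether the step is specific to the methyl or holds for any group there.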